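The compounds below may be only part of what the source reports. "The series", "measured", "known", "first", "only" and "open" are said of these compounds alone.

Three compounds carry a shared core with an arylpiperazine linked through an alkylamine chain, and all three have been examined in an assay on isolated protein for binding affinity to Alpha-1A adrenergic receptor (Homo sapiens), read by radioligand binding; on this read-out lower numbers stand for stronger inhibition and higher numbers for weaker inhibition. Compound 1 `COc1ccccc1N1CCN(CCNc2cc(-c3ccccc3)nn(C)c2=O)CC1` gives 0.22 nM in this assay. Compound 2 `COc1ccc(Cl)cc1N1CCN(CCNc2c(C(C)=O)c(-c3ccccc3)nn(C)c2=O)CC1` gives 0.28 nM in this assay, and compound 3 `COc1ccc(Cl)cc1N1CCN(CCCNc2cc(-c3ccccc3)nn(C)c2=O)CC1` gives 2 nM in this assay. Among these three numbers compound 2 stands second highest; its nearest neighbour is compound 1, whose value lies within the usual scatter of that of compound 2, so no order between these two can be read. Compound 3 gives a higher number than compound 2, and that gap lies beyond the scatter.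

Compound 4 `CC(=O)c1c(-c2ccccc2)nn(C)c(=O)c1NCCN1CCN(c2ccccc2F)CC1` has not yet been measured. It differs from compound 2 in one place: 2-fluorophenyl in place of 5-chloro-2-methoxyphenyl on an amine nitrogen in a ring. Within the data shown here, no measured pair shows this exchange directly, so its effect is open. For compound 4 a modest step toward a higher number in this assay is expected, a 3.2-fold higher number from compound 2 to compound 4 (0.51 log units; beyond the scatter), though a result within the scatter of compound 2 would not surprise. On that basis compound 4 is estimated to give 0.9 nM in this assay, with an expected range from 0.2 nM to 4 nM.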

Compound 4, inhibition constant: 0.32 nM
The estimate for compound 4 lay 2.8-fold (0.45 log units) above the measured number; low and high end bracket the measured number.
By their numbers in this assay, from the lowest: compounds 1, 2 and 4 (each within the scatter of the next); then compound 3.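

Measured in this assay the exchange of 5-chloro-2-methoxyphenyl for 2-fluorophenyl on an amine nitrogen in a ring gives a 1.1-fold higher number from compound 2 to compound 4 (0.06 log units; within the scatter) and so shows no change that can be read. This is the first direct look at this position among the compounds shown, and it indicates that, on the shared core of compound 2, the aryl group can go from 9 heavy atoms to 7 and from 1 hydrogen-bond acceptor to 0 without a readable effect on this number. Nothing in the data at hand explains why the two groups read alike.

Among these compounds, the single pair does not tell whether 2-fluorophenyl would read the same way on the core of compound 1, which has no acetyl group, or with the longer chain of compound 3. The compounds shown also leave open what the chlorine and the methoxy group each contribute, and how a plain phenyl, a 2-hydroxyphenyl or a pyridine ring would read on this nitrogen.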